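Chain amine change from compound 2 to compound 4

This account rests on a few compounds, and the source may have more. Where it says the series, first, only, none or still open, it means among the compounds named here.

Measured in a functional assay on HT-29 cells (Homo sapiens) for cytotoxicity, read by MTT assay, with a stated time of 72 h; on this read-out higher numbers stand for weaker inhibition and lower numbers for stronger inhibition:
compound 1 `CN(C)CCCNc1nc(-c2ccc(NC(=O)Nc3ccc(Cl)cc3)cc2)nc2c(Cl)c(Cl)sc12` — 330 nM
compound 2 `CN(C)CCCNc1nc(-c2ccc(NC(=O)Nc3ccccc3Cl)cc2)nc2c(Cl)c(Cl)sc12` — 820 nM
compound 3 `Cc1ccc(NC(=O)Nc2ccc(-c3nc(NCCCN(C)C)c4sc(Cl)c(Cl)c4n3)cc2)cc1` — 1320 nM

Compound 2 stands second highest of the three numbers. The step of a 2.5-fold higher number from compound 1 to compound 2 (0.40 log units; beyond the scatter) sets it apart from compound 1, whereas the step of a 1.6-fold higher number from compound 2 to compound 3 (0.21 log units; within the scatter) does not separate it from compound 3. The remaining step, a 4.0-fold higher number from compound 1 to compound 3 (0.60 log units; beyond the scatter), likewise lies at the aryl group on the amide-type nitrogen. Compound 4 `CCN(CC)CCCNc1nc(-c2ccc(NC(=O)Nc3ccccc3Cl)cc2)nc2c(Cl)c(Cl)sc12` keeps that end unchanged and differs from compound 2 only in the chain: diethylamino in place of dimethylamino on a saturated chain carbon, three bonds along the chain from a nitrogen on an aromatic ring. Going by the values given here, none of the three measured steps touches the chain amine, so no measured step bears on this change; all three concern the aryl group on the amide-type nitrogen. With no guidance from the series, the expected step of no change at the digits printed from compound 2 to compound 4 (within the scatter) in this assay is none beyond the scatter, though the range must be kept wide. Compound 4 is therefore estimated at about 820 nM in this assay, with a range from 330 nM to 2000 nM.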

Compound 4, half-maximal inhibitory concentration: 410 nM
Estimate against measurement, compound 4: 2.0-fold (0.30 log units) above, and the stated range covers the measured number.
By their numbers in this assay, from the lowest: compounds 1, 4, 2 and 3 (each within the scatter of the next, the first and the last beyond it).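

In this assay, the chain amine now has its first reading, a 2.0-fold lower number from compound 2 to compound 4 (0.30 log units; within the scatter), so diethylamino and dimethylamino are not separated at this place with 2-chlorophenyl on the amide-type nitrogen. Among the compounds shown, the larger dialkylamino group therefore carries no loss of cytotoxic activity beyond the scatter, although this rests on a single pair. No measurement at hand offers an explanation for this reading.

Among the compounds shown, the chain amine varies only with 2-chlorophenyl on the amide-type nitrogen, so it remains open whether the same reading holds with 4-chlorophenyl or 4-methylphenyl there. Also open, on these data alone, is how a cyclic amine such as piperidine or morpholine, or a chain longer than 3-(diethylamino)propyl, would read at this place in this assay.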